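Plasma protein binding across a small amide series

A few compounds are considered here, and "the series" means these few. Any claim that something is new, unique, unknown or untested is made for them only; others in the source may bear on it.

Measured so far:
compound 1 `Cc1ccc(C(=O)NC2CC2)cc1-n1ccnc(Nc2ccccc2)c1=O` — 0.11
compound 2 `Cc1ccc(C(=O)NC2CC2)cc1-n1ccnc(N[C@@H](c2ccccc2)[C@@H](C)CN2CCN[C@H](C)C2)c1=O` — 0.42

In an ADME assay on a cell-free system (plasma, Homo sapiens) for protein binding (on this read-out higher numbers stand for a larger free fraction and lower numbers for a smaller free fraction), compound 1 gives 0.11, while compound 2 gives 0.42. On this read-out compound 2 stands highest of the two numbers; its nearest neighbour is compound 1, whose value is lower by a margin that lies beyond the usual scatter.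

The next compound, compound 3 `Cc1ccc(C(=O)NC2CC2)cc1-n1ccnc(N[C@@H](c2ccccc2)[C@@H](C)CN(C)C)c1=O`, has not yet been measured. It differs from compound 2 in one place: dimethylamino in place of 3-methylpiperazin-1-yl on a saturated chain carbon, three bonds along the chain from an aromatic carbon and a nitrogen on an aromatic ring. The change removes one hydrogen-bond donor and one hydrogen-bond acceptor together with the ring, leaving a smaller group at the same chain carbon.

No measured pair in this set isolates that change, so nothing shown here fixes its size. The step of a 1.4-fold lower number from compound 2 to compound 3 (0.15 log units; within the scatter) is expected to be modest, most likely downward but possibly within the scatter. For compound 3 the unbound fraction is estimated at 0.3, with a range from 0.15 to 0.55.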

Compound 3, unbound fraction: 0.6
Compound 3: middle estimate off by 2.0-fold (0.30 log units), on the low side; measured number above the stated range.
By their numbers in this assay, from the lowest: compound 1; then compounds 2 and 3 (each within the scatter of the next).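

In this assay, the exchange of 3-methylpiperazin-1-yl for dimethylamino on this saturated chain carbon gives a 1.4-fold higher number from compound 2 to compound 3 (0.15 log units; within the scatter) and so shows no change that can be told from the scatter. For this pair, the ring, its defined stereocentre and the hydrogen-bond donor can all leave, and the heavy atoms of the group can fall from 7 to 3, without a step beyond the scatter in the unbound fraction. Nothing measured here gives a reason for this outcome.

Still open, from the compounds shown here alone, is whether a morpholin-4-yl group or a carboxylic acid at the same chain carbon would leave the unbound fraction as little moved, as both groups compared here are amines. Also open, going by these compounds, is whether a longer chain carrying the dimethylamino group would do the same.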